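Working notes: one methoxy removed from compound 1

The source may hold more compounds than are shown below. What is called first, only, known or untested is meant among the compounds shown, and "the series" means these compounds.

Measured so far in a functional assay on DU-145 cells (Homo sapiens) for inhibition, read by trypan blue exclusion, with a stated time of 96 h; on this read-out lower numbers stand for stronger inhibition of growth and higher numbers for weaker inhibition of growth:
Compound 1, `COc1cc(OC)c(/C=C(\C(=O)c2ccc(Br)cc2)S(=O)(=O)c2ccc(Br)cc2)c(OC)c1`: compound 1 gives > 100000 nM, a limit of the assay.
Compound 2, `COc1cc(OC)c(/C=C(\C(=O)c2ccc(Br)cc2)S(=O)(=O)c2ccc(C)cc2)c(OC)c1`: compound 2 gives > 100000 nM, a limit of the assay.
Compound 3, `COc1cc(OC)c(/C=C(/Sc2ccc(C)cc2)C(=O)c2ccc(Br)cc2)c(OC)c1`: compound 3 gives > 100000 nM, a limit of the assay.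

Compound 1 stands at the limit, as do the other two: the limit of > 100000 nM in this assay, at which 3 of the 3 values shown sit. No number is known for any of them, so the steps among them cannot be sized: a step that the two limits leave unreadable from compound 1 to compound 2, a step that the two limits leave unreadable from compound 1 to compound 3 and a step that the two limits leave unreadable from compound 2 to compound 3 all remain unreadable.

Compound 4, `COc1cccc(OC)c1/C=C(\C(=O)c1ccc(Br)cc1)S(=O)(=O)c1ccc(Br)cc1`, differs from compound 1 in one place: hydrogen in place of methoxy on an aromatic carbon. The change sits on an aromatic carbon of a six-membered aromatic ring of carbon only, meta to two methoxy groups. Within the data shown here, none of the measured steps touches this ring; the three measured steps concern the bromo, methyl, (4-methylphenyl)sulfanyl and sulfonyl groups of the shared core, and all three are unreadable. Among the measured compounds shown here, there is therefore no measured step that bears on the change to compound 4, and nothing shows growth inhibition appearing once a methoxy is removed. The expectation is that compound 4 stays at or near the same limit, with the step of a number no higher from compound 1 to compound 4 (the limit leaves the size open) expected to be small or not observable. Compound 4 is estimated at 100000 nM, within 30000 nM to 300000 nM, and most likely reported again only as a limit.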

Compound 4, concentration for 50% growth inhibition: 10000 nM
Beside the measured number, compound 4's estimate is 10-fold (1.00 log units) above it, outside the stated range (below it).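

In this assay, hydrogen in place of methoxy on an aromatic carbon, meta to two methoxy groups and para to a large group, gives an at least 10-fold lower number from compound 1 to compound 4 (1.00 log units; beyond the scatter), so on the core of compound 1 the methoxy at this position is not a silent feature. On these data alone, the upper end of this step remains open, and compound 1 contributes a limit of the assay rather than a number. Compound 4 is the only compound shown with a measured number, and this is the first readable change in the series, with the other three compounds remaining at the limit: the limit of > 100000 nM in this assay, at which 3 of the 4 values shown sit.

As far as these compounds go, the steps among compound 1, compound 2 and compound 3 cannot be read, so it remains open whether the bromo, methyl, (4-methylphenyl)sulfanyl and sulfonyl changes would matter on the core of compound 4, or whether removing this methoxy would have the same result on compound 2 and compound 3. Also open is whether the result depends on the absence of any group at this position, as the compounds shown do not tell how a hydroxyl, a fluoro, an amine or a longer alkoxy chain there would compare with hydrogen or methoxy.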